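Amide-substituted series: cyclohexyl to butyl on the ring nitrogen

The source may report more compounds than this note shows. Statements on the series, on what has been measured and on what is new or still open speak of the compounds shown alone.

Of the compounds shown here, three of a shared core have been measured in a physicochemical assay for lipophilicity; a lower number here means a more polar compound, a higher number a more lipophilic compound. Compound 1 `O=c1oc(NC2CCCCC2)nc2ccccc12` gives 3.5, the lowest of the three numbers recorded. Compound 3 `Cc1ccc2c(=O)oc(NC(C)C)nc2c1C` gives 3.8, which sits within the scatter of compound 1, while compound 2 `Cc1cccc2c(=O)oc(C(C)(C)C)nc12` gives 4, beyond the scatter of compound 1. No pair of these compounds differs in one place only, so no step has been traced between them.

Compound 4 `CCCCNc1nc2ccccc2c(=O)o1` has not yet been measured. Relative to compound 1 it carries butyl in place of cyclohexyl on a nitrogen on an aromatic ring. For this change a drop in the distribution coefficient of a size beyond the usual scatter is expected; the expected step is a number 0.50 log units lower from compound 1 to compound 4 (beyond the scatter). Compound 4 is accordingly estimated at 3, within a range from 2.5 to 3.5.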

Compound 4, distribution coefficient: 3.1
Compound 4: the middle estimate sits 0.10 log units below what was measured; the measured number falls inside the stated range.
By their numbers in this assay, from the lowest: compound 4; then compounds 1, 3 and 2 (each within the scatter of the next, the first and the last beyond it).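

On a nitrogen on an aromatic ring, butyl in place of cyclohexyl gives the first step traced in this series in this assay (a number 0.40 log units lower from compound 1 to compound 4 (beyond the scatter)). The group at this position therefore moves the number beyond the scatter, at least in this one pair on the unsubstituted shared core. Nothing in hand gives a reason for this step.

A single pair cannot separate the loss of the ring from the smaller carbon count; a hexyl chain or a cyclopentyl group at this place would pull the two apart. Going by these compounds, whether the step carries over to the methyl-bearing cores also remains open.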